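The source may hold more compounds than are shown below. What is called first, only, known or untested is meant among the compounds shown, and "the series" means these compounds.

The measured compounds:

compound 1, `O=C(/C=C/c1cccc(O)c1)c1cc(O)c(O)c([N+](=O)[O-])c1`, 55800 nM
compound 2, `N#Cc1cccc(/C=C/C(=O)c2cc(O)c(O)c([N+](=O)[O-])c2)c1`, 60600 nM
compound 3, `CC(=O)N1N=C(c2cc(O)c(O)c([N+](=O)[O-])c2)CC1c1cccc(O)c1`, 85200 nM

All three were tested in an assay on isolated protein for inhibition of Amine oxidase [flavin-containing] B (Homo sapiens), read by fluorescence; on this read-out higher numbers stand for weaker inhibition and lower numbers for stronger inhibition. Compound 1 and compound 2 share one core and differ in a single place: cyano in place of hydroxy on an aromatic carbon. That change gave a 1.1-fold higher number from compound 1 to compound 2 (0.04 log units; within the scatter), so the two compounds cannot be told apart on this read-out. Compound 3 is built on a different core; how its core differs from that of compound 1 is not broken down here. Its value in this assay lies within the usual scatter of both compound 1 and compound 2, so nothing separates the three.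

Compound 4, `CC(=O)N1N=C(c2cc(O)c(O)c([N+](=O)[O-])c2)CC1c1cccc(C#N)c1`, has not yet been measured. It differs from compound 3 in one place: cyano in place of hydroxy on an aromatic carbon. The surroundings of the change are described in the same words for both pairs, so this is the same change already seen between compound 1 and compound 2. Because that earlier change produced a 1.1-fold higher number from compound 1 to compound 2 (0.04 log units; within the scatter), the step in this assay is expected to be small as well, at a 1.1-fold higher number from compound 3 to compound 4 (0.02 log units; within the scatter). Since the earlier pair gave no clear movement, the expectation rests on a single precedent and carries wide uncertainty. Compound 4 is therefore estimated at 90000 nM in this assay, with a likely range from 45000 nM to 180000 nM.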

Compound 4, half-maximal inhibitory concentration: 55400 nM
Estimate against measurement, compound 4: 1.6-fold (0.21 log units) above, within the range that was stated.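

Replacing the hydroxy with a cyano, which turns a 3-hydroxyphenyl into a 3-cyanophenyl, on the core of compound 3 gave a 1.5-fold lower number from compound 3 to compound 4 (0.19 log units; within the scatter) in this assay, so these two compounds cannot be told apart on this read-out. Set beside the same change on the core of compound 1, the two steps do not differ by more than ordinary measurement noise would allow: the same change on two cores in this assay, a 1.1-fold higher number (0.04 log units; within the scatter) from compound 1 to compound 2 and a 1.5-fold lower number (0.19 log units; within the scatter) from compound 3 to compound 4, 1.7-fold (0.22 log units) apart, within the scatter of two such steps This shows that in both pairs the swap left the number within the scatter, and that this lack of clear movement held on two different cores, but it does not show that the change has exactly the same effect on each core, since two steps this small offer little to compare and neither of them rises clearly above the noise.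

On these data alone, it remains open whether a different group in the same place, such as an amine, a carboxylic acid or a longer chain, would move the number beyond the scatter. Also open is how much the nitro group and the two hydroxy groups matter, as all of the compounds shown carry them unchanged.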